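The source may hold more compounds than are shown below. What is called first, only, known or untested is meant among the compounds shown, and "the series" means these compounds.

In a functional assay on the whole organism with Mus musculus as the target, in the writhing test (a higher number here means that more compound is needed for the effect, a lower number that less compound is needed), compound 1 `FC(F)(F)CCCSc1nsnc1C1CN2CCCC1C2` gives 0.1 mg/kg, a measured number. Compound 2 `CN1CCC=C(c2nsnc2SCCCc2ccccc2)C1` differs from compound 1 in more than one place. The reading for compound 2 is a limit of the assay and not a number: > 10 mg/kg. Compound 2 therefore has no exact position on the scale, and only the limit marks where it stands.

Compound 3 `CN1CCC=C(c2nsnc2SCCCc2cccs2)C1` departs from compound 2 at a single place, the far end of the side chain. It carries thiophen-2-yl in place of phenyl on a saturated chain carbon, three bonds along the chain from a sulfur. The same difference, cut one bond further out, reads benzyl to (thiophen-2-yl)methyl.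

Among the measured compounds shown here, no pair of measured compounds differs in one place only, so the data offer no direct guide to the size of such a change. In this assay, no shift beyond the usual scatter is expected, and the expected change is a step that the limit leaves unreadable from compound 2 to compound 3. The assay may well report only a limit again. The estimated value for compound 3 is 15 mg/kg, within an expected range of 4 mg/kg to 50 mg/kg.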

Compound 3, dose for half-maximal effect: > 10 mg/kg
Compound 3: a limit, no number; the forecaster's own chance of this, stated with the estimate: 65%; the middle value is on the limit's open side.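

In this assay compound 3 gives a limit and not a number, > 10 mg/kg. Compound 2 also stands at a limit, so no step can be read between compound 2 and compound 3. The compounds shown leave open where either one stands on the scale, and whether thiophen-2-yl in place of phenyl changes the dose at all.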